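This account rests on a few compounds, and the source may have more. Where it says the series, first, only, none or still open, it means among the compounds named here.

Compound 2, `COP(=O)(OC)OC[C@H]1O[C@@H](n2cnc3c(NC4CCCC4)nc(Cl)nc32)[C@H](O)[C@@H]1O`, gives 1400 nM in an in vitro functional assay on HEK-293T cells for agonist activity at adenosine receptor A1 (Homo sapiens), read by a luciferase reporter and cAMP accumulation, with a stated time of 10 min; on this read-out higher numbers stand for an effect only at larger amounts of compound and lower numbers for an effect already at smaller amounts. Among the two compounds measured so far it stands with the highest number, the other being compound 1, `O=P(O)(O)OC[C@H]1O[C@@H](n2cnc3c(NC4CCCC4)nc(Cl)nc32)[C@H](O)[C@@H]1O`, which in this assay gives 72 nM. Among the measured compounds shown here, the one step measured between them, a 19-fold higher number from compound 1 to compound 2 (1.29 log units; beyond the scatter), replaces a free phosphate with a dimethyl phosphate on the sugar.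

Compound 3, `COP(=O)(OC)OC[C@H]1O[C@@H](n2cnc3c(NC4CCCC4)ncnc32)[C@H](O)[C@@H]1O`, differs from compound 2 in a different part of the molecule: hydrogen in place of chloro on an aromatic carbon. The change lies on an aromatic carbon of a six-membered aromatic ring with 2 nitrogen, between two ring nitrogen atoms, far from the sugar phosphate that was varied before. For the measured compounds named here, no measured step touches this position, so the only step seen, from compound 1 to compound 2, does not bear on it and its size carries no direct lesson here.

Without a comparable step, the expectation for compound 3 in this assay rests on the change being a single small atom removed: the estimated step is a 2.1-fold higher number from compound 2 to compound 3 (0.33 log units; beyond the scatter), a modest rise in the number rather than a large one. Compound 3 is therefore expected to give about 3000 nM in this assay, within a range from 1000 nM to 10000 nM.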

Compound 3, half-maximal effective concentration: 4400 nM
The estimate for compound 3 lay 1.5-fold (0.17 log units) below the measured number; the measured number falls inside the stated range.
By their numbers in this assay, from the lowest: compound 1; then compound 2; then compound 3.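

In this assay, the step of a 3.1-fold higher number from compound 2 to compound 3 (0.50 log units; beyond the scatter) shows that this aromatic carbon, between two ring nitrogen atoms, has a real bearing on the read-out: exchanging the chloro, a single heavy atom, for hydrogen gives a modest change that lies beyond the usual scatter. This is also the first measured change away from the sugar phosphate, and with the dimethyl phosphate held constant, the chloro compound is the one that acts at smaller amounts. Nothing available here explains this shift.

As far as these compounds go, the pair carries only the dimethyl phosphate, so it remains open whether hydrogen in place of chloro would change the number to a similar extent in a compound otherwise matching compound 1, with its free phosphate. From the compounds shown here alone, it is equally open how a bromo, a methyl or an amine on the same carbon would compare, and so whether the lower number belongs to chloro alone or would also appear with other groups at this position.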